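Cell toxicity notes: from compound 3 to compound 4

A few compounds are considered here, and "the series" means these few. Any claim that something is new, unique, unknown or untested is made for them only; others in the source may bear on it.

Measured so far:
compound 1, `O=[N+]([O-])c1cccc(NC(=S)NCCNS(=O)(=O)c2ccc(-c3ccccc3OCc3ccccc3)s2)c1`, 18300 nM
compound 2, `O=C(NCCNS(=O)(=O)c1ccc(-c2ccccc2O[C@H]2CC[C@@H](O)CC2)s1)Nc1cc(C(F)(F)F)cc(C(F)(F)F)c1`, 14100 nM
compound 3, `CC(C)c1ccc(Oc2ccc(O)c(O)c2)c(-c2ccsc2S(=O)(=O)NCCNC(=S)Nc2cc(C(F)(F)F)cc(C(F)(F)F)c2)c1`, 18100 nM

All three numbers come from an ADME assay on HEK-293T cells (Homo sapiens) for cytotoxicity, read by CCK-8 assay, with a stated time of 48 h; on this read-out higher numbers stand for weaker inhibition and lower numbers for stronger inhibition. Compound 1 gives 18300 nM, compound 2 gives 14100 nM and compound 3 gives 18100 nM. Compound 3 stands second highest of the three numbers; its nearest neighbour is compound 1, whose number lies within the scatter of it, and the furthest is compound 2, also within the scatter. The three measured compounds therefore sit together, and no order among them can be read from these numbers.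

Compound 4, `COc1ccc(Oc2ccc(C(C)C)cc2-c2ccsc2S(=O)(=O)NCCNC(=S)Nc2cc(C(F)(F)F)cc(C(F)(F)F)c2)cc1OC`, is not yet measured in this assay. It differs from compound 3 in one place: 3,4-dimethoxyphenyl in place of 3,4-dihydroxyphenyl on an oxygen on an aromatic ring

Going by the values given here, no pair of measured compounds differs in a single place, so there is no measured step to lean on for this change. Compound 1 at 18300 nM, compound 2 at 14100 nM and compound 3 at 18100 nM sit together although they differ in several places. On that basis the step is expected to be a 1.1-fold lower number from compound 3 to compound 4 (0.03 log units; within the scatter), none beyond the scatter in either direction. The estimate for compound 4 in this assay is 17000 nM, with a range from 8000 nM to 36000 nM.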

Compound 4, half-maximal inhibitory concentration: 10200 nM
Estimate against measurement, compound 4: 1.7-fold (0.22 log units) above, within the range that was stated.
By their numbers in this assay, from the lowest: compounds 4, 2, 3 and 1 (each within the scatter of the next).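

In this assay, going by these compounds alone, the replacement of 3,4-dihydroxyphenyl by 3,4-dimethoxyphenyl on an oxygen on an aromatic ring gives the first step that can be read at a single place: a 1.8-fold lower number from compound 3 to compound 4 (0.25 log units; within the scatter) and so no shift that stands clear of repeat measurements. At this position, going from 2 hydrogen-bond donors to 0 leaves the number in this cell read-out without a readable change, so this pair gives no sign that the free hydroxyl groups matter for it. No measured property is available that would explain this result.

Open, going by these compounds, is whether the two hydroxyl groups count separately, which a ring carrying one hydroxyl and one methoxy would address, and whether the position stays this flat with groups of another kind, such as an amine or a carboxylic acid on the ring, or a longer chain on the oxygens. This single step also leaves open whether the same replacement reads alike on other cores, such as that of compound 1 or compound 2.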